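The source may report more compounds than this note shows. Statements on the series, on what has been measured and on what is new or still open speak of the compounds shown alone.

The measured compounds, with their values in a functional assay on HT-29 cells (Homo sapiens) for cytotoxicity, read by XTT assay, with a stated time of 72 h; a lower number here means a stronger inhibitor, a higher number a weaker inhibitor:

Compound 1, `COc1ccc(C(=O)c2cc(OC)c(OC)c(OC)c2)cc1[N+](=O)[O-]`, gives 2900 nM.
Compound 2, `COc1ccc(Cc2cc(OC)c(OC)c(OC)c2)cc1N`, gives 41 nM.
Compound 3, `COc1ccc(Cc2cc(OC)c(OC)c(OC)c2)cc1[N+](=O)[O-]`, gives 60 nM.

Compound 1 stands apart from compound 2 and compound 3 with the highest number of the three, both other numbers lying far beyond the scatter from it. How the core of compound 1 differs from that of compound 3 is not broken down here. Compound 3 and compound 2 differ in one place only, (amino in place of nitro on an aromatic carbon), and that change produced a 1.5-fold lower number from compound 3 to compound 2 (0.17 log units; within the scatter).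

Compound 4, `COc1ccc(C(=O)c2cc(OC)c(OC)c(OC)c2)cc1N`, is unmeasured. It arises from compound 1 by the same change, (amino in place of nitro on an aromatic carbon), made at a place described in the same words. Because a 1.5-fold lower number from compound 3 to compound 2 (0.17 log units; within the scatter) lay within the scatter, the step from compound 1 to compound 4 is expected to be small as well, a 1.3-fold lower number from compound 1 to compound 4 (0.12 log units; within the scatter). Compound 4 is therefore estimated to give about 2200 nM in this assay, likely between 700 nM and 7000 nM.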

Compound 4, half-maximal inhibitory concentration: 32 nM
The estimate for compound 4 lay 69-fold (1.84 log units) above the measured number, and the stated range ends above it.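

In this assay, amino in place of nitro on an aromatic carbon produced a 91-fold lower number from compound 1 to compound 4 (1.96 log units; beyond the scatter). The size of this change did not carry over from one core to the other: the same change on two cores in this assay, a 1.5-fold lower number (0.17 log units; within the scatter) from compound 3 to compound 2 and a 91-fold lower number (1.96 log units; beyond the scatter) from compound 1 to compound 4, 62-fold (1.79 log units) apart, beyond the scatter of two such steps

With only these two pairs, the result shows that the step depends on the core here, but it does not show why, nor what the same change would do on any further core. The compounds shown leave open how other groups on that aromatic carbon, such as a hydroxyl, a methylamino group or an acetamide, would compare on either core.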